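A few compounds are considered here, and "the series" means these few. Any claim that something is new, unique, unknown or untested is made for them only; others in the source may bear on it.

Measured compounds:
- compound 1, `COc1cc2c(Oc3ccc(NC(=O)c4nn(-c5ccccc5C(F)(F)F)c(=O)cc4C)cc3F)ccnc2cc1OCCCN1CCN(C)CC1`, in a functional assay on MKN-45 cells (Homo sapiens) for inhibition, read by MTT assay, with a stated time of 72 h (on this read-out higher numbers stand for weaker inhibition and lower numbers for stronger inhibition), gives 40 nM
- compound 2, `COc1cc2c(Oc3ccc(NC(=O)c4nn(-c5ccccc5OC(F)(F)F)c(=O)cc4C)cc3F)ccnc2cc1OCCCN1CCCC1`, in this assay gives 60 nM

Compound 2 carries the highest of the two numbers, but its nearest neighbour, compound 1, sits within the usual scatter of it, so the two values show no difference that can be read as real. Within the data shown here, compound 1 and compound 2 differ in more than one place, so no single step between them is drawn.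

Compound 3, `COc1cc2c(Oc3ccc(NC(=O)c4nn(-c5ccccc5OC(F)(F)F)c(=O)cc4C)cc3F)ccnc2cc1OCCCN1CCN(C)CC1`, is not yet measured. It departs from compound 2 by one change: 4-methylpiperazin-1-yl in place of pyrrolidin-1-yl on a saturated chain carbon, three bonds along the chain from an oxygen on an aromatic ring. The shared core, the amide and the trifluoromethoxy-bearing phenyl ring stay as they are in compound 2.

Among the measured compounds shown here, nothing among the measured compounds isolates this amine change on its own. Compound 1, which carries the same 4-methylpiperazin-1-yl group on the same chain, sits within the scatter of compound 2, which speaks against any large movement. The step from compound 2 to compound 3 is therefore expected to be small, a 1.3-fold lower number from compound 2 to compound 3 (0.12 log units; within the scatter), not beyond the scatter in either direction. Compound 3 is estimated at 45 nM, with a range from 20 nM to 100 nM.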

Compound 3, half-maximal inhibitory concentration: 100 nM
Compound 3: middle estimate off by 2.2-fold (0.35 log units), on the low side; the measured number falls inside the stated range.
By their numbers in this assay, from the lowest: compounds 1, 2 and 3 (each within the scatter of the next, the first and the last beyond it).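

In this assay, among these compounds, the amine on this saturated chain carbon is now varied on its own for the first time: with the trifluoromethoxy-bearing ring held constant, placing 4-methylpiperazin-1-yl where pyrrolidin-1-yl stood gives a 1.7-fold higher number from compound 2 to compound 3 (0.22 log units; within the scatter), so this pair shows no readable difference between the two ring amines. The second new step holds the 3-(4-methylpiperazin-1-yl)propyl chain constant and puts trifluoromethoxy in place of trifluoromethyl on an aromatic carbon, giving a 2.5-fold higher number from compound 1 to compound 3 (0.40 log units; beyond the scatter), a modest change and the only step among these compounds that lies beyond the scatter. No measurement shown here accounts for either step.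

On these data alone, whether the trifluoromethoxy-for-trifluoromethyl step would be of the same size with pyrrolidin-1-yl on the chain remains open, since that comparison rests on the 4-methylpiperazin-1-yl pair alone. Also open, as far as these compounds go, is how this assay would read with other amines on the same chain carbon, such as morpholin-4-yl or dimethylamino, or with a 2-(4-methylpiperazin-1-yl)ethyl chain in place of the propyl one.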